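The compounds below may be only part of what the source reports. "The series", "measured", "known", "first", "only" and "open" are said of these compounds alone.

Notes on the series. Compound 1 `COc1cccc(C(C)Sc2nc3c(cnn3C)c(=O)n2-c2ccccc2)c1` gives 174 nM in an assay on isolated protein for inhibition of Retinaldehyde dehydrogenase 3 (Homo sapiens); on this read-out lower numbers stand for stronger inhibition and higher numbers for weaker inhibition. Compound 2 `CC(Sc1nc2c(cnn2C)c(=O)n1-c1ccccc1)c1cccc(F)c1` gives 128 nM in this assay, and compound 3 `CC(Sc1nc2c(cnn2C)c(=O)n1-c1ccccc1)c1cccnc1` gives 95 nM. The first two sit close: a 1.4-fold lower number from compound 1 to compound 2 (0.13 log units; within the scatter). Compound 3 carries the lowest of the three numbers, yet none of its steps to the others leaves the scatter, so it cannot be set apart from compound 2 or compound 1.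

Compound 4 `COc1ccccc1C(C)Sc1nc2c(cnn2C)c(=O)n1-c1ccccc1` is not yet measured in this assay. Its difference from compound 3: 2-methoxyphenyl in place of pyridin-3-yl on a saturated chain carbon bound to a saturated chain carbon and a sulfur. Going by the values given here, the steps that bear on this change are the two earlier swaps of the ring on this same chain carbon, a 1.8-fold lower number from compound 1 to compound 3 (0.26 log units; within the scatter) and a 1.3-fold lower number from compound 2 to compound 3 (0.13 log units; within the scatter), both within the scatter. A change of ring at this place has so far moved the number little, so no step beyond the scatter is expected in this assay, in either direction. For compound 4 the expected value is 150 nM, within 60 nM to 400 nM. The step this estimate implies, a 1.6-fold higher number from compound 3 to compound 4 (0.20 log units; within the scatter), is expected to stay within the scatter.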

Compound 4, half-maximal inhibitory concentration: 112 nM
Compound 4: the middle estimate sits 1.3-fold (0.13 log units) above what was measured; measured number inside the range.
By their numbers in this assay, from the lowest: compounds 3, 4, 2 and 1 (each within the scatter of the next).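

In this assay, the saturated chain carbon bound to a saturated chain carbon and a sulfur also accepts 2-methoxyphenyl with no step beyond the scatter against any earlier ring: pyridin-3-yl (a 1.2-fold higher number from compound 3 to compound 4 (0.07 log units; within the scatter)), 3-fluorophenyl (a 1.1-fold lower number from compound 2 to compound 4 (0.06 log units; within the scatter)) and 3-methoxyphenyl (a 1.6-fold lower number from compound 1 to compound 4 (0.19 log units; within the scatter)). The last of these steps is new in kind, since 2-methoxyphenyl and 3-methoxyphenyl cannot be told apart here, and all four aromatic rings at this place now read as one group of numbers. Nothing at hand accounts for this flat response.

Open, going by these compounds, is whether a group without a ring at this carbon, such as a longer alkyl chain, or a ring bearing an amine or a carboxylic acid, would hold the number in the same range. Also open, on these data alone, is whether any change at this place can produce a step beyond the scatter in this assay.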